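The compounds below may be only part of what the source reports. "The series", "measured", "known", "first", "only" and "open" are said of these compounds alone.

Measured compounds:
- Compound 1 `CNc1ncnc2c1c(-c1ccsc1)cn2[C@@H]1O[C@H](CO)[C@@H](O)[C@H]1O` — > 100000 nM
- Compound 2 `Cc1ncnc2c1c(-c1cc3ccccc3o1)cn2[C@@H]1O[C@H](CO)[C@@H](O)[C@H]1O` — 84400 nM

In an ADME assay on MRC5 cells (Homo sapiens), read by MTT assay, with a stated time of 72 h (a lower number here means a stronger inhibitor, a higher number a weaker inhibitor), compound 1 reaches only the limit of the assay, > 100000 nM, not a number. Compound 2 gives the only number shown, 84400 nM, in this assay. No step between measured compounds is shown; the two values are a weak number and a limit, (the limit of > 100000 nM in this assay, at which 1 of the 2 values shown sits). Compound 3 `CNc1ncnc2c1c(-c1cc3ccccc3o1)cn2[C@@H]1O[C@H](CO)[C@@H](O)[C@H]1O` is not yet measured. It differs from compound 2 by methylamino in place of methyl on an aromatic carbon. The expected step of a 1.2-fold higher number from compound 2 to compound 3 (0.07 log units; within the scatter) is none beyond the scatter, or a small one toward weaker inhibition. Compound 3 is estimated at 100000 nM, from 40000 nM to 300000 nM.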

Compound 3, half-maximal inhibitory concentration: 75300 nM
Estimate against measurement, compound 3: 1.3-fold (0.12 log units) above, within the range that was stated.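

On the aromatic carbon next to the ring nitrogen, methylamino in place of methyl gives a 1.1-fold lower number from compound 2 to compound 3 (0.05 log units; within the scatter) in this assay, so the two groups cannot be told apart here. With methylamino in place on both compounds, 1-benzofuran-2-yl in place of thiophen-3-yl gives an at least 1.3-fold lower number from compound 1 to compound 3 (0.12 log units; that floor lies within the scatter), which is only a floor, so neither group can be ranked over the other. Compound 1 gives a limit, not a number: the limit of > 100000 nM in this assay, at which 1 of the 3 values shown sits.

Going by these compounds, whether a plain amine or a morpholine at that carbon would move the number beyond the scatter stays open.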